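Replacing the Aryl Group on the Sulfonyl Sulfur

The source may hold more compounds than are shown below. What is called first, only, known or untested is meant among the compounds shown, and "the series" means these compounds.

compound 1 `Cc1ccccc1S(=O)(=O)c1ccc(CNC(=O)c2cc3cnccc3[nH]2)cc1`: 48%
compound 2 `O=C(NCc1ccc(S(=O)(=O)c2ccccc2)cc1)c1ccc2nccn2c1`: 77%

In an ADME assay on microsomes from liver (Homo sapiens) for metabolic stability, read by LC-MS, with a stated time of 30 min, tested at 1 uM (a higher number here means that more of the compound is left, a lower number that less of the compound is left), compound 1 gives 48%, the lower of the two numbers. Compound 2 gives 77%. The gap between these two numbers lies beyond the scatter. Compound 3 `O=C(NCc1ccc(S(=O)(=O)c2cccc(C(F)(F)F)c2)cc1)c1cc2cnccc2[nH]1` keeps the core of compound 1 but has 3-(trifluoromethyl)phenyl in place of 2-methylphenyl on a sulfonyl sulfur. Going by the values given here, no measured pair tests this change, so only a loose expectation is possible: a moderate rise. The expected step is a number 12 percentage points higher from compound 1 to compound 3 (beyond the scatter). For compound 3 the estimate is 60%, with an expected range from 40% to 80%.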

Compound 3, percent of the compound remaining: 81%
Compound 3: middle estimate off by 21 percentage points, on the low side, and the stated range ends below it.
By their numbers in this assay, from the lowest: compound 1; then compounds 2 and 3 (each within the scatter of the next).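

With the core of compound 1 held fixed, the aryl group on the sulfonyl sulfur proves decisive on its own: in this assay, 3-(trifluoromethyl)phenyl in place of 2-methylphenyl gives a number 33 percentage points higher from compound 1 to compound 3 (beyond the scatter). Going by these compounds alone, this is the first pair differing in one place, so the large step belongs to this change alone. Nothing available explains the step. This single pair cannot separate the loss of 2-methylphenyl from the arrival of 3-(trifluoromethyl)phenyl. As far as these compounds go, how a cyclopropyl group on the sulfonyl sulfur would read remains open.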